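Swapping an Aromatic Ester for a Nitrooxyethyl Ester

The source may report more compounds than this note shows. Statements on the series, on what has been measured and on what is new or still open speak of the compounds shown alone.

This study concerns esters built on one shared core, each carrying an acetylsalicyloyl group and a second ester group, and it tracks how long they survive in an ADME assay on a cell-free system (plasma, Homo sapiens) for metabolic stability, with Plasma (Rattus norvegicus) as the target, read by HPLC, at pH 7.4; a lower number here means that the compound disappears faster, a higher number that the compound lasts longer. Compound 1 `CC(=O)Oc1ccccc1C(=O)O[C@H]1CO[C@H]2[C@@H]1OC[C@H]2O`, whose second position bears only a hydrogen on oxygen, gives 0.0183 h. Compound 2 `CC(=O)Oc1ccccc1C(=O)O[C@H]1CO[C@H]2[C@@H]1OC[C@H]2OC(=O)c1ccc(C)cc1` carries a (4-methylphenyl)carbonyl there and gives 0.0362 h. Compound 3 `CC(=O)Oc1ccccc1C(=O)O[C@H]1CO[C@H]2[C@@H]1OC[C@H]2OC(=O)c1ccccc1OC(=O)c1ccccc1` gives 0.0722 h. On these numbers compound 2 sits between compound 1 and compound 3, and both gaps lie within the usual scatter of this assay, so no ordering among the three can be claimed.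

Going by the values given here, the one measured step, a 2.0-fold higher number from compound 1 to compound 2 (0.30 log units; within the scatter), is the only guide. Compound 4 `CC(=O)Oc1ccccc1C(=O)O[C@H]1CO[C@H]2[C@@H]1OC[C@H]2OC(=O)CCO[N+](=O)[O-]` differs from compound 2 as follows: 2-(nitrooxy)ethyl in place of 4-methylphenyl on a carbonyl carbon. Among the compounds with values here, no measured pair exchanges one acyl group for another of this kind, so there is no direct precedent for the change.

Within the data shown here, since the single relevant step was within the scatter, compound 4 is expected to behave much like compound 2, with a step of a 1.2-fold lower number from compound 2 to compound 4 (0.08 log units; within the scatter). The estimate for compound 4 in this assay is 0.03 h, with a likely range from 0.012 h to 0.08 h.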

Compound 4, half-life: 0.0217 h
Estimate against measurement, compound 4: 1.4-fold (0.14 log units) above; the measured number falls inside the stated range.
By their numbers in this assay, from the lowest: compounds 1, 4, 2 and 3 (each within the scatter of the next, the first and the last beyond it).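

In this assay, the exchange of 4-methylphenyl for 2-(nitrooxy)ethyl on a carbonyl carbon gives a 1.7-fold lower number from compound 2 to compound 4 (0.22 log units; within the scatter) and is the first exchange shown of one acyl group for another at this position. The entering chain has no ring and carries 3 hydrogen-bond acceptors, while the leaving group has a six-membered aromatic ring and none, yet this large difference in structure does not move the half-life beyond the scatter. Placing (2-(nitrooxy)ethyl)carbonyl in place of hydrogen on the oxygen gives a 1.2-fold higher number from compound 1 to compound 4 (0.07 log units; within the scatter) and so cannot be told apart from the parent with its free hydroxyl, and nothing measured here offers a reason for any of these numbers.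

On these data alone, whether an acyl group ending in an amine or a carboxylic acid, or a longer chain ending in the same nitrooxy group, would give a half-life clearly apart from these values remains open. The acetylsalicyloyl ester and the shared core also stay the same throughout, so the compounds shown cannot tell what a change in either part would do.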